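From Nitro to Phenyl on the Aromatic Carbon

The compounds below may be only part of what the source reports. "The series", "measured", "known", "first", "only" and "open" are said of these compounds alone.

Of the compounds shown here, three sharing one core have been measured in a physicochemical assay for acid dissociation, using potentiometric titration. Compound 1 `N#C/C(=N\O)C(=O)Nc1cc(C(F)(F)F)cc(C(F)(F)F)c1` gives 4.73, compound 2 `N#C/C(=N\O)C(=O)Nc1cc(F)cc(F)c1` gives 4.81, and compound 3 `N#C/C(=N\O)C(=O)Nc1ccc([N+](=O)[O-])cc1` gives 4.61. Compound 3 holds the lowest of the three numbers, yet both its nearest neighbour, compound 1, and its furthest, compound 2, sit within the scatter of it, so the three cannot be told apart with confidence. Compound 4 `N#C/C(=N\O)C(=O)Nc1ccc(-c2ccccc2)cc1` has not yet been measured. It differs from compound 3 in one place: phenyl in place of nitro on an aromatic carbon. Within the data shown here, no step between measured compounds covers this change, so the expectation rests on the narrow band the three measured compounds occupy. A small upward step, at about the edge of the scatter, is expected: a number 0.34 log units higher from compound 3 to compound 4 (beyond the scatter). Compound 4 is therefore estimated at 4.95, with a range from 4.7 to 5.2.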

Compound 4, acid dissociation constant: 5.03
Compound 4: the middle estimate sits 0.08 log units below what was measured, within the range that was stated.
By their numbers in this assay, from the lowest: compounds 3, 1, 2 and 4 (each within the scatter of the next, the first and the last beyond it).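

In this assay, among these compounds, phenyl in place of nitro on an aromatic carbon, para to a group of 8 heavy atoms, gives a number 0.42 log units higher from compound 3 to compound 4 (beyond the scatter) and is the first change in one place that can be read in this set. It shows that, for this pair, the number moves with the group at this position. Nothing given here accounts for the step. One pair cannot separate the departure of nitro from the arrival of phenyl. Going by these compounds, what an amine or a carboxylic acid would give at this position remains open.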